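This account rests on a few compounds, and the source may have more. Where it says the series, first, only, none or still open, it means among the compounds named here.

Compound 1 `O=C(Nc1cccc(/C=C/C(=O)c2nc3ccccc3[nH]2)c1)c1cccc(Cl)c1` and compound 2 `Cc1cccc(C(=O)Nc2cccc(/C=C/C(=O)c3nc4ccccc4[nH]3)c2)c1` share the same core and differ only on the outer ring. In a functional assay on 143B cells (Homo sapiens) for antiproliferative activity, read by MTT assay, with a stated time of 48 h (on this read-out higher numbers stand for weaker inhibition and lower numbers for stronger inhibition), compound 1 gives 3370 nM, while compound 2 gives 4880 nM; compound 2 thus sits at the top of the two numbers shown, though the step of a 1.4-fold higher number from compound 1 to compound 2 (0.16 log units; within the scatter) lies within the scatter, so the two are not distinguished. Compound 3 `Cc1cccc(S(=O)(=O)Nc2cccc(/C=C/C(=O)c3nc4ccccc4[nH]3)c2)c1` carries (3-methylphenyl)sulfonyl in place of (3-methylphenyl)carbonyl on a nitrogen on an aromatic ring. Among the measured compounds shown here, no measured step bears on this change; the only step in hand, methyl in place of chloro, was within the scatter, so nothing points either way. Compound 3 is therefore expected to give 5500 nM, in a range from 2000 nM to 15000 nM, an expected step of a 1.1-fold higher number from compound 2 to compound 3 (0.05 log units; within the scatter).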

Compound 3, half-maximal inhibitory concentration: 791 nM
The estimate for compound 3 lay 7.0-fold (0.84 log units) above the measured number; the whole stated range lies above it.
By their numbers in this assay, from the lowest: compound 3; then compounds 1 and 2 (each within the scatter of the next).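

Replacing (3-methylphenyl)carbonyl with (3-methylphenyl)sulfonyl on the nitrogen gives a 6.2-fold lower number from compound 2 to compound 3 (0.79 log units; beyond the scatter), so this position responds to the linking group in a way the methyl-for-chloro exchange on the outer ring did not show. The same holds against the chloro compound, with a 4.3-fold lower number from compound 1 to compound 3 (0.63 log units; beyond the scatter). No measurement given here explains this gain. The compounds shown leave open whether a (3-chlorophenyl)sulfonyl group on the same nitrogen would match compound 3, and how a plain methylene link in place of the sulfonyl would read.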